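From methoxy to methylamino on a shared core

A few compounds are considered here, and "the series" means these few. Any claim that something is new, unique, unknown or untested is made for them only; others in the source may bear on it.

Going by the values given here, in a functional assay on HepG2 cells (Homo sapiens) for antiproliferative activity, read by XTT assay, with a stated time of 72 h (a higher number here means a weaker inhibitor, a lower number a stronger inhibitor), compound 1 (`C#Cc1cn([C@@H]2O[C@H](CO)[C@@H](O)[C@H]2O)c2ncnc(OC)c12`) gives 12700 nM as its half-maximal inhibitory concentration, the higher of the two numbers measured so far. Compound 3 (`C#Cc1cn([C@@H]2O[C@H](CO)[C@@H](O)[C@H]2O)c2ncnc(NC)c12`) has not yet been measured. It keeps the core of compound 1 and changes one group, with methylamino in place of methoxy on an aromatic carbon. Among the compounds with values here, no measured pair isolates this change, since compound 2 (`CNc1ncnc2c1c(-c1ccco1)cn2[C@@H]1O[C@H](CO)[C@@H](O)[C@H]1O`) differs from compound 1 in more than one place. Within the data shown here, compound 2 does carry the same methylamino group, and it gives 850 nM in this assay as the only guide available. On that slender evidence, a moderate step toward a lower number is expected, probably beyond the scatter, though a result close to compound 1 cannot be ruled out. The expected change is a 6.4-fold lower number from compound 1 to compound 3 (0.80 log units; beyond the scatter) as an estimated shift. For compound 3 the estimated value is 2000 nM in the same read-out, with an expected range from 300 nM to 10000 nM as its bounds.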

Compound 3, half-maximal inhibitory concentration: > 15000 nM
Compound 3 gave a limit, no number; the forecaster's own chance of this, stated with the estimate: 3%; middle value at least 7.5-fold (0.87 log units) from the limit.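

In this assay compound 3 gives a limit of the assay and not a number: the limit of > 15000 nM in this assay, at which 1 of the 3 values shown sits. With ethynyl kept in place, methylamino in place of methoxy on an aromatic carbon gives an at least 1.1-fold higher number from compound 1 to compound 3 (0.07 log units; that floor lies within the scatter), so this pair shows no move toward a lower number, and its floor alone does not fix how large the true step is. With methylamino kept in place, ethynyl in place of furan-2-yl on an aromatic carbon gives an at least 17-fold higher number from compound 2 to compound 3 (1.24 log units; beyond the scatter), which shows that methylamino by itself does not bring the lower number seen with furan-2-yl and that the choice between these two groups carries a large step in this assay.

From the compounds shown here alone, it remains open how far the true value of compound 3 lies past its limit, and so whether methoxy and methylamino differ at all when ethynyl is present. The compounds shown also leave open whether furan-2-yl would bring the same gain alongside methoxy, and how a plain amino group or a dimethylamino group would compare with methylamino on the shared core.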